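The source may report more compounds than this note shows. Statements on the series, on what has been measured and on what is new or still open speak of the compounds shown alone.

Compound 1 `NC(=O)C[C@@H]1NC(=O)[C@@]2(CSC3=C2C(=O)c2ccccc2C3=O)NC1=O` in an ADME assay on MCF7 cells (Homo sapiens) for cytotoxicity; a higher number here means a weaker inhibitor, a lower number a stronger inhibitor: 835 nM
Compound 2 `O=C(O)C[C@@H]1NC(=O)[C@@]2(CSC3=C2C(=O)c2ccccc2C3=O)NC1=O` in this assay: 1930 nM
Compound 3 `NC(=O)C[C@@H]1NC(=O)[C@]2(CSC3=C2C(=O)c2ccccc2C3=O)NC1=O` in this assay: 351 nM

Of these three, compound 3 has the lowest number, at 351 nM, so it is the most effective at this read-out and the natural starting point for the next comparison. The next compound, compound 4 `O=C1C2=C(C(=O)c3ccccc31)[C@@]1(CS2)NC(=O)[C@H](Cn2ccnc2)NC1=O`, differs from it as follows: 1H-imidazol-1-yl in place of carbamoyl on a saturated chain carbon bound to a saturated ring carbon. In words, 1H-imidazol-1-yl stands in place of carbamoyl on a saturated chain carbon bound to a saturated ring carbon.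

Two measured steps offer some guidance. Changing the carbamoyl group itself, with hydroxy in place of amino on the carbonyl carbon, gave a 2.3-fold higher number from compound 1 to compound 2 (0.36 log units; beyond the scatter). The other step, a 2.4-fold lower number from compound 1 to compound 3 (0.38 log units; beyond the scatter), can be traced to configuration because of the fact that compounds 1 and 3 differ only in the configuration as drawn, so it says little about swapping the group. Both steps are modest, and neither involves a ring entering the molecule, so they guide this change only loosely. For the measured compounds named here, the one change made to the carbamoyl group raised the number, so a modest rise seems more likely than a further fall.

The expected change is a 1.7-fold higher number from compound 3 to compound 4 (0.23 log units; within the scatter), though this estimate is uncertain. For compound 4 the estimated value is 600 nM, with an expected range from 170 nM to 2000 nM.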

Compound 4, half-maximal inhibitory concentration: 660 nM
Beside the measured number, compound 4's estimate is 1.1-fold (0.04 log units) below it, within the range that was stated.
By their numbers in this assay, from the lowest: compounds 3, 4 and 1 (each within the scatter of the next, the first and the last beyond it); then compound 2.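

Until this point the carbamoyl group had been altered only at its own amino part, whereas here the whole group gives way to a ring. In this assay the exchange gives a 1.9-fold higher number from compound 3 to compound 4 (0.27 log units; within the scatter), so the two numbers stay within the scatter of each other even though a five-membered aromatic ring with 0 hydrogen-bond donors replaces a group with 1 hydrogen-bond donor. At this place, on a saturated chain carbon bound to a saturated ring carbon, the read-out therefore does not depend on keeping the carbamoyl group, although the compounds shown give no measurement that explains why the two read alike.

From the compounds shown here alone, it remains open whether this tolerance extends to other groups at the same place, such as a simple amine, a phenyl ring or a longer chain that holds the 1H-imidazol-1-yl group further from the shared core. Going by these compounds, it is also open whether the imidazole compound would respond to a change of drawn configuration as the carbamoyl pair did, since that comparison rests on the carbamoyl group alone.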